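Swapping a Cyclopentyl for a Butyl on the Core

This account rests on a few compounds, and the source may have more. Where it says the series, first, only, none or still open, it means among the compounds named here.

Measured in a functional assay on HCT-116 cells (Homo sapiens) for antiproliferative activity, read by CCK-8 assay, with a stated time of 72 h, tested at 8 uM; a lower number here means a weaker effect, a higher number a stronger effect of the compound at the concentration tested:
- compound 1 `CC(C)n1cnc2c(Nc3ccccc3)nc(NCOCc3ccc(/C=C/C(=O)Nc4ccccc4N)cc3)nc21` gives 41.7%
- compound 2 `Nc1ccccc1NC(=O)/C=C/c1ccc(Cn2cnc3c(Nc4cccc(OC(F)(F)F)c4)nc(Cl)nc32)cc1` gives 5.23%
- compound 3 `Nc1ccccc1NC(=O)c1ccc(COCNc2nc(Nc3ccccc3)c3ncn(C4CCCC4)c3n2)cc1` gives 76.9%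

Compound 3 stands highest of the three numbers in this assay. Its nearest neighbour, compound 1, lies well beyond the scatter below it, and compound 2 lies further still, so compound 3 is the most active of the measured set.

Compound 4 `CCCCn1cnc2c(Nc3ccccc3)nc(NCOCc3ccc(C(=O)Nc4ccccc4N)cc3)nc21` keeps everything of compound 3 except one group: butyl in place of cyclopentyl on an aromatic nitrogen. Within the data shown here, no pair of measured compounds differs by this change alone, so the effect of the butyl in place of cyclopentyl is unknown from these data. The step from compound 3 to compound 4 in this assay is expected to be small, most likely a modest loss or none beyond the scatter, a number 11.9 percentage points lower from compound 3 to compound 4 (beyond the scatter). Compound 4 is therefore estimated at 65%, within a range from 40% to 85%.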

Compound 4, a percentage reported as inhibition, at one concentration (the size of the read-out at that concentration, not a potency): 74.9%
For compound 4 the middle estimate is 9.9 percentage points below the measured one, within the range that was stated.
By their numbers in this assay, from the lowest: compound 2; then compound 1; then compounds 4 and 3 (each within the scatter of the next).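

In this assay, butyl in place of cyclopentyl on an aromatic nitrogen gives a number 2 percentage points lower from compound 3 to compound 4 (within the scatter), so this open chain and this carbon ring read alike at this position. For this pair, then, the read-out does not depend on the ring being present. Nothing at hand explains why the two groups match.

From the compounds shown here alone, both groups contain only carbon, so it remains open how a chain ending in an amine or a carboxylic acid would read here. A longer chain, such as octyl, is also untested among the compounds shown.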